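Thiazolyl ketone sulfides: aryl exchange on the pyrimidinone ring

The source may report more compounds than this note shows. Statements on the series, on what has been measured and on what is new or still open speak of the compounds shown alone.

Measured so far:
compound 1 `Cc1nc(-c2ccc(Cl)cc2)sc1C(=O)CSc1nc(-c2ccc(Cl)c(Cl)c2)c(C#N)c(=O)[nH]1` — 93.9%
compound 2 `Cc1nc(-c2ccccc2)sc1C(=O)CSc1nc(-c2ccc(Cl)c(Cl)c2)c(C#N)c(=O)[nH]1` — 75.3%
compound 3 `Cc1nc(-c2ccccc2)sc1C(=O)CSc1nc(N)c(C#N)c(-c2ccccc2)n1` — 26.3%

In a functional assay on U-87MG ATCC cells for antiproliferative activity against U-87 MG (Homo sapiens), read by MTT assay, with a stated time of 48 h, tested at 50 uM (a lower number here means a stronger effect, a higher number a weaker effect of the compound at the concentration tested), compound 1 gives 93.9%, the highest of the three numbers and therefore the weakest effect in the set; its nearest neighbour is compound 2, and compound 3 lies furthest from it. Among the measured compounds shown here, the only step measured within one place of change is a number 18.6 percentage points lower from compound 1 to compound 2 (beyond the scatter), a modest move on the aryl attached to the thiazole. For the measured compounds named here, compound 3 differs from compound 1 at several places at once, so its value shows only that a different core reaches a much lower number.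

Compound 4 `COc1ccc(-c2nc(SCC(=O)c3sc(-c4ccc(Cl)cc4)nc3C)[nH]c(=O)c2C#N)cc1OC` is the untested member: 3,4-dimethoxyphenyl in place of 3,4-dichlorophenyl on an aromatic carbon. Going by the values given here, no measured step touches this position on the core of compound 1, so the step from compound 2 gives no direct guide. With nothing to anchor a direction, the expectation for compound 4 is a number close to compound 1, with a wide allowance, so a number 8.9 percentage points lower from compound 1 to compound 4 (within the scatter) is expected to stay small. Compound 4 is thus estimated at 85%, between 60% and 100%.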

Compound 4, a percentage reported as activity, at one concentration (the size of the read-out at that concentration, not a potency): 59.8%
For compound 4 the middle estimate is 25.2 percentage points above the measured one; measured number below the stated range.
By their numbers in this assay, from the lowest: compound 3; then compound 4; then compound 2; then compound 1.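

In this assay, the step shows that this place responds strongly to the aryl group it carries: a number 34.1 percentage points lower from compound 1 to compound 4 (beyond the scatter), with 3,4-dimethoxyphenyl in place of 3,4-dichlorophenyl giving the stronger effect at the concentration tested. Among the compounds shown here, this is the first measured change on this aromatic carbon ortho to a cyano group, as the earlier single-place step touched a different aryl group. No measurement available here accounts for the shift.

Still open, as far as these compounds go, is whether a phenyl carrying one methoxy group, or an aryl bearing a dimethylamino group or a carboxylic acid, would lower the number further at this place. From the compounds shown here alone, it is also open whether the same exchange would have a similar effect on compound 2, where the other aryl group has no chloro substituent.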